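Difluorophenyl for methoxyphenyl on the carbonyl: an expectation

The source may hold more compounds than are shown below. What is called first, only, known or untested is meant among the compounds shown, and "the series" means these compounds.

Three members of the series have been run in a functional assay on MDA-MB-435 cells (Homo sapiens) for cytotoxicity, read by sulforhodamine B assay, with a stated time of 48 h, tested at 0.01 uM; a lower number here means a stronger effect, a higher number a weaker effect of the compound at the concentration tested. Compound 1 `COc1cc(-c2cc(/C=C/C(=O)c3ccc(N)cc3)[nH]n2)cc(OC)c1OC` gives 90%. Compound 2 `COc1ccc(-c2cc(/C=C/C(=O)c3ccc(N)cc3)[nH]n2)cc1` gives 97%. Compound 3 `COc1ccc(C(=O)/C=C/c2cc(-c3cc(OC)c(OC)c(OC)c3)n[nH]2)cc1` gives 99%. Compound 3 stands highest of the three numbers, but its nearest neighbour compound 2 sits only slightly lower, within the scatter, and compound 1 is the furthest, also within the scatter. Among the compounds with values here, the one single-point step so far, a number 9 percentage points higher from compound 1 to compound 3 (within the scatter), is therefore without effect beyond the scatter, and all three read-outs cluster at the weak end of the scale at the concentration tested.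

Compound 4 `COc1cc(-c2cc(/C=C/C(=O)c3ccc(F)c(F)c3)[nH]n2)cc(OC)c1OC` is not yet measured in this assay. It differs from compound 3 as follows: 3,4-difluorophenyl in place of 4-methoxyphenyl on a carbonyl carbon. Within the data shown here, no measured step touches this aryl group on the carbonyl carbon; the only step in hand concerns the amino-to-methoxy exchange and was within the scatter. With nothing in the data pointing either way, the expectation for compound 4 is a number close to that of compound 3, and the step of a number 4 percentage points lower from compound 3 to compound 4 (within the scatter) is expected to stay within the scatter. Compound 4 is estimated at 95%, with a range from 82% to 105%.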

Compound 4, a percentage reported as activity, at one concentration (the size of the read-out at that concentration, not a potency): 98%
The estimate for compound 4 lay 3 percentage points below the measured number; the range from low to high includes it.
By their numbers in this assay, from the lowest: compounds 1, 2, 4 and 3 (each within the scatter of the next).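

With compound 4 in hand, the aryl group on the carbonyl carbon has been varied three ways on the shared core, covering 4-aminophenyl, 4-methoxyphenyl and 3,4-difluorophenyl, and no exchange at this position has yet produced a step beyond the scatter in this assay. Replacing the oxygen-bearing 4-methoxyphenyl with the fluorine-bearing 3,4-difluorophenyl gives a number 1 percentage points lower from compound 3 to compound 4 (within the scatter), and replacing 4-aminophenyl with the same group gives a number 8 percentage points higher from compound 1 to compound 4 (within the scatter), so at this single concentration the read-out does not separate these three aryl groups, all of them carbon-only aromatic rings of six members. No independent measurement bears on this result or offers an account of it.

These readings cluster at the weak end of the scale, so they leave open whether the three aryl groups would separate at a higher concentration, where a fuller response could be read. Also open, from the compounds shown here alone, is whether a more different group on the carbonyl carbon, such as a carboxylic acid on the phenyl ring, a pyridine ring in place of the phenyl ring, or a simple alkyl chain, would give a step beyond the scatter.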